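A few compounds are considered here, and "the series" means these few. Any claim that something is new, unique, unknown or untested is made for them only; others in the source may bear on it.

Measured compounds in the series:
compound 1 `CCC(CC)(c1ccc(OCCO)c(C)c1)c1ccc(OCC(O)C(C)(C)C)c(OCC(O)C(C)(C)C)c1` — 38%
compound 2 `CCC(CC)(c1ccc(OCCCCO)c(C)c1)c1ccc(OCC(O)C(C)(C)C)c(OCC(O)C(C)(C)C)c1` — 71%

In an assay on cells for binding affinity to vitamin D3 receptor (Homo sapiens), read by fluorescence, tested at 1 uM (on this read-out lower numbers stand for less inhibition and higher numbers for more inhibition at the one concentration tested (going by the name of the read-out)), compound 1 gives 38%, and compound 2 gives 71%. Compound 2 stands highest of the two numbers measured; its nearest neighbour is compound 1, and the change between them is a number 33 percentage points higher from compound 1 to compound 2 (beyond the scatter). Within the data shown here, that is the only step in hand, and it concerns the same hydroxy-terminated chain on the aromatic oxygen.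

The next compound, compound 3 `CCC(CC)(c1ccc(OCCCCCO)c(C)c1)c1ccc(OCC(O)C(C)(C)C)c(OCC(O)C(C)(C)C)c1`, has not been measured in this assay. It differs from compound 2 by hydroxymethyl in place of hydroxy on a saturated chain carbon, four bonds along the chain from an oxygen on an aromatic ring, which extends that same chain by one more link. Among the measured compounds shown here, the one step that bears on it is the earlier one, which was large and upward. Whether a further link continues that rise cannot be read from two points; a smaller upward move or a flat result is expected rather than another large jump, so the step of a number 5 percentage points higher from compound 2 to compound 3 (within the scatter) is estimated as modest. Compound 3 is therefore expected to give about 76%, within a range from 58% to 92%.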

Compound 3, a percentage reported as inhibition, at one concentration (the size of the read-out at that concentration, not a potency): 67%
The estimate for compound 3 lay 9 percentage points above the measured number; the measured number falls inside the stated range.
By their numbers in this assay, from the lowest: compound 1; then compounds 3 and 2 (each within the scatter of the next).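

In this assay the change to hydroxymethyl in place of hydroxy, on a saturated chain carbon, four bonds along the chain from an oxygen on an aromatic ring, gives a number 4 percentage points lower from compound 2 to compound 3 (within the scatter) and so leaves the two chains unresolved on this read-out. The large difference from the short chain therefore holds for a second chain length, with a number 29 percentage points higher from compound 1 to compound 3 (beyond the scatter) and with compound 2 and compound 3 forming one group set apart from compound 1. Nothing in hand gives a reason for this picture.

The compounds shown leave open how the read-out runs with a longer chain than that of compound 3, and whether the hydroxy itself is needed, which an amine or a carboxylic acid in its place at the end of the chain would test. From the compounds shown here alone, all three numbers come from a single concentration, so whether compound 2 and compound 3 also match in potency remains open.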